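The source may hold more compounds than are shown below. What is called first, only, known or untested is meant among the compounds shown, and "the series" means these compounds.

Compound 1 `Cc1ccccc1NC(=O)Nc1cc(C(C)(C)C)nn1-c1ccccc1`, compound 2 `CC(C)(C)c1cc(NC(=O)Nc2ccccc2)n(-c2ccccc2)n1` and compound 3 `CC(C)(C)c1cc(NC(=O)Nc2cc(F)cc(F)c2)n(-c2ccccc2)n1` share one core and differ only in the ring carried on an amide-type nitrogen. In an assay on isolated protein for inhibition of serine/threonine-protein kinase 10 (Homo sapiens), read by thermal shift assay, tested at 10 uM (a higher number here means that the compound stabilises the target more against heat, a lower number that the compound stabilises the target less), compound 1 gives 8.6 degrees C, compound 2 gives 7.2 degrees C and compound 3 gives 2.5 degrees C, the lowest of the three; the drops a number 6.1 degrees C lower from compound 1 to compound 3 (beyond the scatter) and a number 4.7 degrees C lower from compound 2 to compound 3 (beyond the scatter) are both large. Compound 4 `Cc1ccc(-n2nc(C(C)(C)C)cc2NC(=O)Nc2cc(F)cc(F)c2)cc1` differs from compound 3 by methyl in place of hydrogen on an aromatic carbon. Going by the values given here, the only measured step of this kind, a number 1.4 degrees C lower from compound 1 to compound 2 (beyond the scatter), concerned a methyl on a different aromatic carbon and was modest, so the reverse change here is expected to lift the reading at most slightly, by about a number 0.70 degrees C higher from compound 3 to compound 4 (within the scatter), or not beyond the scatter. Compound 4 is therefore estimated at 3.2 degrees C, between 1.2 degrees C and 5.2 degrees C.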

Compound 4, shift of the target's melting temperature: 0.6 degrees C
Beside the measured number, compound 4's estimate is 2.6 degrees C above it; the measured number lies below the stated range.
By their numbers in this assay, from the lowest: compound 4; then compound 3; then compound 2; then compound 1.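

At this position, the change from phenyl to 4-methylphenyl does not leave the reading unchanged, but gives a number 1.9 degrees C lower from compound 3 to compound 4 (beyond the scatter). A methyl on this ring therefore goes with a lower reading, whereas the methyl that separates compound 1 from compound 2 goes with a higher one, so the direction of the methyl step differs between these two pairs: the same change on two cores in this assay, a number 1.4 degrees C lower (beyond the scatter) from compound 1 to compound 2 and a number 1.9 degrees C higher (beyond the scatter) from compound 4 to compound 3, 3.3 degrees C apart, beyond the scatter of two such steps.

Going by these compounds, whether an ethyl or a methoxy group at this place would lower the reading further stays open. So does whether 4-methylphenyl would lower it with the unsubstituted phenyl of compound 2 on the amide-type nitrogen.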